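A Methyl Added Where Cytotoxicity Was Already Beyond Reach

A few compounds are considered here, and "the series" means these few. Any claim that something is new, unique, unknown or untested is made for them only; others in the source may bear on it.

Of the compounds shown here, two have been tested in a toxicity assay on HeLa cells (Homo sapiens) for cytotoxicity, read by MTT assay, with a stated time of 24 h; a lower number here means a stronger inhibitor, a higher number a weaker inhibitor. Compound 1 `Cc1ncc([N+](=O)[O-])n1CC(O)CSC(=S)N1CCN(c2ccccc2F)CC1` gives 3240000 nM. Compound 2 `Cc1ncc([N+](=O)[O-])n1CC(O)Cn1cnc([N+](=O)[O-])c1` reaches only a limit of the assay in this assay, > 5000000 nM. Compound 2 thus stands at the limit of > 5000000 nM in this assay, at which 1 of the 2 values shown sits, the weaker end of what was measured. Compound 3 `Cc1nc([N+](=O)[O-])cn1CC(O)Cn1c([N+](=O)[O-])cnc1C` differs from compound 2 by methyl in place of hydrogen on an aromatic carbon. Going by the values given here, no measured pair bears on this change, so in this assay nothing beyond the usual scatter is expected from compound 2 to compound 3. Compound 3 is therefore expected to give about 6000000 nM, within 2500000 nM to 15000000 nM, the expected step being a step that the limit leaves unreadable from compound 2 to compound 3.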

Compound 3, half-maximal inhibitory concentration: 4350000 nM
Compound 3: the middle estimate sits 1.4-fold (0.14 log units) above what was measured; the measured number falls inside the stated range.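

With methyl in place of hydrogen on the aromatic carbon between two ring nitrogen atoms, this assay gives an at least 1.1-fold lower number from compound 2 to compound 3 (0.06 log units; that floor lies within the scatter), the first step read at this position. Compound 3 gives a true number, 4350000 nM, so the methyl-bearing compound falls inside the range of the assay. How large the step really is cannot be told because compound 2 carries only a limit of the assay: the limit of > 5000000 nM in this assay, at which 1 of the 3 values shown sits.

On these data alone, whether an amine, a carboxylic acid or a longer chain at this position would move the number further stays open. A single change here shows no trend.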